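Sulfoxide analogues: shortening the aryl chain in the xanthine series

A few compounds are considered here, and "the series" means these few. Any claim that something is new, unique, unknown or untested is made for them only; others in the source may bear on it.

The series is built on one shared core, varied at a sulfur-linked side chain. Compound 1 `COc1ccc(CCSc2nc3c(c(=O)n(C)c(=O)n3C)n2C)cc1` gives 168000 nM in an assay on microsomes for inhibition of Amine oxidase [flavin-containing] A (Homo sapiens), read by fluorescence and spectrophotometry, with a stated time of 20 min (a lower number here means a stronger inhibitor, a higher number a weaker inhibitor), and compound 2 `COc1cccc(CCSc2nc3c(c(=O)n(C)c(=O)n3C)n2C)c1` gives 48100 nM. The single one-place step among these, a 3.5-fold lower number from compound 1 to compound 2 (0.54 log units; beyond the scatter), is a change of methoxyphenyl substitution pattern on the chain. Compound 3 `Cn1c(=O)c2c(nc([S+]([O-])CCc3ccc(Br)cc3)n2C)n(C)c1=O` carries the sulfoxide and a bromophenyl chain and gives 57300 nM; it stands second highest of the three numbers, with compound 2 nearest and within the scatter of it, and compound 1 furthest, beyond the scatter, so compound 3 sits among the weaker inhibitors here without separating from compound 2.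

Compound 4 `Cn1c(=O)c2c(nc([S+]([O-])Cc3ccccc3)n2C)n(C)c1=O` is the next analogue: phenyl in place of 4-bromobenzyl on a saturated chain carbon bound to a sulfur. Within the data shown here, no measured step removes a halogen or shortens the chain by a carbon, so only the aryl-substitution step from compound 1 to compound 2 bears on it, and that step was modest and of a different kind. The change in compound 4 is therefore expected to move this assay by little more than the scatter, if at all, with a slight lean toward a higher number, estimated as a 1.6-fold higher number from compound 3 to compound 4 (0.20 log units; within the scatter). Compound 4 is estimated at 90000 nM, within a range of 30000 nM to 300000 nM.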

Compound 4, half-maximal inhibitory concentration: 250000 nM
Beside the measured number, compound 4's estimate is 2.8-fold (0.44 log units) below it; low and high end bracket the measured number.
By their numbers in this assay, from the lowest: compounds 2 and 3 (each within the scatter of the next); then compounds 1 and 4 (each within the scatter of the next).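

In this assay, phenyl in place of 4-bromobenzyl on a saturated chain carbon bound to a sulfur gives a 4.4-fold higher number from compound 3 to compound 4 (0.64 log units; beyond the scatter), so this position on the sulfoxide side chain does respond to change, and in the direction of weaker inhibition. The earlier step, a 3.5-fold lower number from compound 1 to compound 2 (0.54 log units; beyond the scatter), only moved a methoxy group around the aryl ring with the chain left intact, whereas this one takes the group from 8 heavy atoms to 6 and removes the bromine, and the series now has a readable step in each direction. No measurement in hand accounts for the rise in the number from compound 3 to compound 4.

Still open, going by these compounds, is how much of the step belongs to the bromine and how much to the carbon that leaves with it, since the two change together here and a plain benzyl group at this place would separate them. Also open, on these data alone, is how this assay reads a longer chain, or a chain ending in an amine or a carboxylic acid, at the same sulfur.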